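From Phenoxy to Chloro at an Assay Limit

This account rests on a few compounds, and the source may have more. Where it says the series, first, only, none or still open, it means among the compounds named here.

In an ADME assay on HEK293 cells (Homo sapiens) for cytotoxicity, read by luminescence, with a stated time of 72 h (on this read-out higher numbers stand for an effect only at larger amounts of compound and lower numbers for an effect already at smaller amounts), compound 2 (`CCOC(=O)c1c(-c2cccc(Oc3ccccc3)c2)[nH]c2cc(OC)c(F)cc2c1=O`) gives > 22000 nM as its result, which is a limit and not a number. In this assay compound 1 (`CCOC(=O)c1c(-c2cccc(Cl)c2)[nH]c2cc(OC)c(Cl)cc2c1=O`) gives > 22000 nM as its result, and that too is a limit. The record so far consists of the limit of > 22000 nM in this assay, at which 2 of the 2 values shown sit, and so compound 2 cannot be ranked against any other compound.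

Compound 3 (`CCOC(=O)c1c(-c2cccc(Cl)c2)[nH]c2cc(OC)c(F)cc2c1=O`) is reached from compound 2 with chloro in place of phenoxy on an aromatic carbon, meta to a large group (chloro in place of phenoxy on an aromatic carbon). For the measured compounds named here, no step between measured compounds is available to gauge such a change. In this assay no step beyond the scatter is expected in either direction, and compound 3 is expected to end at a limit as well. That expectation rests on compound 2 with > 22000 nM as its limit, and nothing closer has been measured. The expected change is a step that the limit leaves unreadable from compound 2 to compound 3 and it stays within the scatter. For compound 3 the estimated value is 25000 nM with an expected range from 14000 nM to 50000 nM around that estimate.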

Compound 3, half-maximal effective concentration: > 22000 nM
Compound 3 gave a limit, no number; the forecaster's own chance of this, stated with the estimate: 85%; the middle value does not contradict the limit.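

Compound 3 also ends at a limit and not at a number, so no step to it from compound 1 or compound 2 can be read in this assay, and the three compounds cannot be ranked: the limit of > 22000 nM in this assay, at which 3 of the 3 values shown sit.

What the compounds shown leave open is whether chloro in place of phenoxy, or fluoro in place of chloro, changes the result in this assay at all.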